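The source may hold more compounds than are shown below. What is called first, only, known or untested is meant among the compounds shown, and "the series" means these compounds.

- Compound 1 `O=C(OCCc1c(-c2ccccc2Cl)c2cc(Cl)ccc2[nH]c1=O)C1CCCC1` gives 46000 nM
- Compound 2 `COc1ccccc1/C=C/C(=O)OCCc1c(-c2ccccc2Cl)c2cc(Cl)ccc2[nH]c1=O` gives 770000 nM

In an ADME assay on HepG2 2.2.15 cells (Homo sapiens) for cytotoxicity (a higher number here means that more compound is tolerated, a lower number that less compound is tolerated), compound 2, at 770000 nM, holds the higher of the two numbers. Compound 3 `COc1ccc(/C=C/C(=O)OCCc2c(-c3ccccc3Cl)c3cc(Cl)ccc3[nH]c2=O)cc1OC` carries this change from compound 2: 3,4-dimethoxyphenyl in place of 2-methoxyphenyl on a double-bonded chain carbon bound to a double-bonded chain carbon, with the ethenyl chain kept. Among the measured compounds shown here, the only measured step, a 17-fold higher number from compound 1 to compound 2 (1.22 log units; beyond the scatter), was large and beyond the scatter, but it exchanged cyclopentyl for the whole 2-(2-methoxyphenyl)ethenyl. For the measured compounds named here, no measured step covers the present exchange, so that step bears on it only loosely, and no step beyond the scatter is expected. The estimated step is a 1.5-fold lower number from compound 2 to compound 3 (0.19 log units; within the scatter), in the downward direction. For compound 3 the expected value is 500000 nM, with an estimated range from 150000 nM to 1500000 nM in this assay.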

Compound 3, half-maximal cytotoxic concentration: > 1200000 nM
Compound 3: no number, only a limit (the forecaster's own chance of this, stated with the estimate: 15%); middle value at least 2.4-fold (0.38 log units) from the limit.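

In this assay compound 3 gives > 1200000 nM, which is a limit of the assay and not a number. As far as these compounds go, at this place, 3,4-dimethoxyphenyl in place of 2-methoxyphenyl gives an at least 1.5-fold higher number from compound 2 to compound 3 (0.19 log units; that floor lies within the scatter), so the true size of this change remains unknown. Exchanging cyclopentyl on the carbonyl carbon gives an at least 26-fold higher number from compound 1 to compound 3 (1.41 log units; beyond the scatter), so the large step now holds for a second substituted phenyl ethenyl group.

Open, from the compounds shown here alone, is how an unsubstituted phenyl or a hydroxyl-bearing phenyl would stand at this place. Also open, going by these compounds, is whether a saturated ethyl chain would serve in place of the ethenyl chain.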